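Working notes: a bromo step on compound 1

The source may report more compounds than this note shows. Statements on the series, on what has been measured and on what is new or still open speak of the compounds shown alone.

Compound 1 `COc1ccc(CNc2c(-c3ccccc3O)nc3ccccn23)cc1` gives 15 nM
Compound 2 `COc1ccc(CNc2c(-c3ccccc3NC(C)=O)nc3ccccn23)cc1` gives > 10000 nM (a limit)

Going by the values given here, both readings come from a functional assay on HeLa cells (Homo sapiens) for cytotoxicity, read by sulforhodamine B assay, with a stated time of 3 days (a higher number here means a weaker inhibitor, a lower number a stronger inhibitor), and compound 1 holds the only actual number so far. Compound 3 `COc1ccc(CNc2c(-c3ccccc3O)nc3ccc(Br)cn23)cc1` changes the core of compound 1 as follows: bromo in place of hydrogen on an aromatic carbon. Among the compounds with values here, the one measured step, an at least 660-fold higher number from compound 1 to compound 2 (2.82 log units; beyond the scatter), is large but concerns acetamido in place of hydroxy at another place, so it offers no direct guide to this change. A modest step toward a weaker inhibitor is therefore only a cautious expectation. In this assay the expected change is a 2.7-fold higher number from compound 1 to compound 3 (0.43 log units; beyond the scatter). Compound 3 is estimated at 40 nM, within a range of 8 nM to 400 nM.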

Compound 3, half-maximal inhibitory concentration: 810 nM
The estimate for compound 3 lay 20-fold (1.31 log units) below the measured number, outside the stated range (above it).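

In this assay the core itself proves sensitive, not only the hydroxy group: bromo in place of hydrogen on an aromatic carbon gives a 54-fold higher number from compound 1 to compound 3 (1.73 log units; beyond the scatter). This place, two atoms from the ring nitrogen, therefore tolerates bromo poorly, although compound 3 still gives a real number rather than a limit. Nothing at hand accounts for the size of this step.

As far as these compounds go, whether the loss belongs to bromo itself or to any group at this place stays open. Fluoro, methyl or an amine here would separate the two readings.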